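Swapping (oxiran-2-yl)methoxy for methyl in compound 3

A few compounds are considered here, and "the series" means these few. Any claim that something is new, unique, unknown or untested is made for them only; others in the source may bear on it.

In a functional assay on U-251 cells (Homo sapiens) for cytotoxicity (a higher number here means a weaker inhibitor of growth, a lower number a stronger inhibitor of growth), compound 3 (`CSc1ccc(C2=C(c3ccc(OCC4CO4)cc3)C(=O)N3CCCC3C2)cc1`) gives 80 nM, the lowest of the three measured numbers, with compound 2 (`CSc1ccc(C2=C(c3ccc(F)c(C)c3)C(=O)N3CCCC3C2)cc1`) at 200 nM and compound 1 (`COc1ccc(C2=C(c3ccc(SC)cc3)CC3CCCN3C2=O)cc1Br`) at 800 nM. Compound 4 (`CSc1ccc(C2=C(c3ccc(C)cc3)C(=O)N3CCCC3C2)cc1`) differs from compound 3 by methyl in place of (oxiran-2-yl)methoxy on an aromatic carbon. Going by the values given here, the one measured step, a 4.0-fold lower number from compound 1 to compound 2 (0.60 log units; beyond the scatter), involves different groups, so it offers only a rough guide to size. Compound 2, which also bears a methyl group, stands at 200 nM. A modest step towards a higher number is therefore expected, estimated as a 2.5-fold higher number from compound 3 to compound 4 (0.40 log units; beyond the scatter). Compound 4 is expected at 200 nM, with an estimated range of 70 nM to 500 nM.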

Compound 4, concentration for 50% growth inhibition: 400 nM
Compound 4: the middle estimate sits 2.0-fold (0.30 log units) below what was measured; the range from low to high includes it.
By their numbers in this assay, from the lowest: compound 3; then compounds 2, 4 and 1 (each within the scatter of the next, the first and the last beyond it).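

In this assay, the aromatic carbon para to a large group responds clearly to this change, with a 5.0-fold higher number from compound 3 to compound 4 (0.70 log units; beyond the scatter) as (oxiran-2-yl)methoxy gives way to methyl. By contrast, a 2.0-fold higher number from compound 2 to compound 4 (0.30 log units; within the scatter) and a 2.0-fold lower number from compound 1 to compound 4 (0.30 log units; within the scatter) both stay within the scatter, so compound 4 cannot be separated from either compound. No evidence on hand accounts for the step from (oxiran-2-yl)methoxy to methyl. As far as these compounds go, it remains open whether the three-membered ring or the ether oxygen matters here. A methoxy group, a longer ether chain or an amine at this carbon would help separate the two.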